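Changing the Amide Aryl Group: Compound 2 to Compound 3

The source may hold more compounds than are shown below. What is called first, only, known or untested is meant among the compounds shown, and "the series" means these compounds.

Compound 1 (`O=C(COc1ccc2cc(/C=C3/SC(=O)NC3=O)ccc2c1)Nc1ccccn1`) in an assay on isolated protein for inhibition of histone deacetylase 8 (Homo sapiens), with a stated time of 1 h (on this read-out lower numbers stand for stronger inhibition and higher numbers for weaker inhibition), gives > 50000 nM, which is a limit of the assay rather than a number. Compound 2 (`O=C(COc1ccc2cc(/C=C3/SC(=O)NC3=O)ccc2c1)Nc1c(F)cc(F)cc1Br`) in this assay gives > 50000 nM, likewise a limit. Compound 2 therefore stands at the limit, as the limit of > 50000 nM in this assay, at which 2 of the 2 values shown sit, shows, and the step that the two limits leave unreadable from compound 1 to compound 2 cannot be read. Compound 3 (`O=C(COc1ccc2cc(/C=C3/SC(=O)NC3=O)ccc2c1)Nc1ccc(Br)c(Br)c1`) differs by 3,4-dibromophenyl in place of 2-bromo-4,6-difluorophenyl on an amide-type nitrogen. Going by the values given here, no measured step speaks readably to this change. Compound 3 is expected to remain at the limit as well, an expected step of a number no higher from compound 2 to compound 3 (the limit leaves the size open). Compound 3 is estimated at 50000 nM, with a range from 10000 nM to 100000 nM.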

Compound 3, half-maximal inhibitory concentration: > 50000 nM
Compound 3 gave a limit, no number; the forecaster's own chance of this, stated with the estimate: 80%; the middle value lies on the limit itself.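

No step among compound 1, compound 2 and compound 3 can be read, as all three give only a limit, not a number: the limit of > 50000 nM in this assay, at which 3 of the 3 values shown sit.

The compounds shown leave open whether any group on the amide nitrogen gives a measurable number in this assay.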